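A few compounds are considered here, and "the series" means these few. Any claim that something is new, unique, unknown or untested is made for them only; others in the source may bear on it.

- Compound 1 `Clc1ccc(-c2cc(-c3ccoc3)cc(-c3ccco3)n2)s1`: 1280 nM
- Compound 2 `Cc1ccccc1-c1cc(-c2ccoc2)cc(-c2ccc(Cl)s2)n1`: 990 nM
- Compound 3 `Cc1cccc(-c2cc(-c3ccoc3)cc(-c3ccc(Cl)s3)n2)c1`: 880 nM

In a functional assay on HCT-15 cells (Homo sapiens) for cytotoxicity, read by ELISA, with a stated time of 4 days (on this read-out higher numbers stand for weaker inhibition and lower numbers for stronger inhibition), compound 3 gives 880 nM, level with compound 1 and compound 2 once the scatter is allowed for. Compound 4 `Clc1cccc(-c2cc(-c3ccoc3)cc(-c3ccc(Cl)s3)n2)c1` has chloro in place of methyl on an aromatic carbon, meta to a large group, so that 3-methylphenyl becomes 3-chlorophenyl.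

Within the data shown here, no measured pair shows this exchange directly. The nearest evidence is the 3-methylphenyl in place of 2-methylphenyl step, a 1.1-fold lower number from compound 2 to compound 3 (0.05 log units; within the scatter). The two exchanges of furan-2-yl are also small: a 1.3-fold lower number from compound 1 to compound 2 (0.11 log units; within the scatter) for 2-methylphenyl, and a 1.5-fold lower number from compound 1 to compound 3 (0.16 log units; within the scatter) for 3-methylphenyl. Across these three compounds, then, changing this substituent has not moved the number beyond the scatter, although that is thin support for a new group.

No shift beyond the scatter is therefore expected, and the estimated step is a 1.0-fold lower number from compound 3 to compound 4 (0.02 log units; within the scatter). For compound 4 the expected value is 850 nM, with an estimated range from 420 nM to 1700 nM.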

Compound 4, half-maximal inhibitory concentration: 950 nM
Compound 4: the middle estimate sits 1.1-fold (0.05 log units) below what was measured, within the range that was stated.
By their numbers in this assay, from the lowest: compounds 3, 4, 2 and 1 (each within the scatter of the next).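

In this assay, the exchange of methyl for chloro on an aromatic carbon, meta to a large group, gives a direct reading at this position: a 1.1-fold higher number from compound 3 to compound 4 (0.03 log units; within the scatter) shows that 3-chlorophenyl and 3-methylphenyl cannot be told apart here. The new group also stays level with the others at this place, with a 1.0-fold lower number from compound 2 to compound 4 (0.02 log units; within the scatter) and a 1.3-fold lower number from compound 1 to compound 4 (0.13 log units; within the scatter) as the remaining steps, so the four groups shown, from furan-2-yl to 3-chlorophenyl, all lie within the scatter of one another. Nothing available accounts for this flat picture.

From the compounds shown here alone, whether an amine or a carboxylic acid at this place would give a step beyond the scatter stays open. So does the effect of any change elsewhere on the shared core, which all four compounds keep the same.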